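Trimming a Naphthalene to a Phenyl on the Ketone Chain

The source may hold more compounds than are shown below. What is called first, only, known or untested is meant among the compounds shown, and "the series" means these compounds.

Of the compounds shown here, three have so far been measured in a functional assay on CCRF-CEM/VCR-1000 cells (Homo sapiens) for inhibition; a lower number here means a stronger inhibitor, a higher number a weaker inhibitor. Compound 1 `COC(CCc1ccccc1)c1ccccc1OCC(O)CN(C(C)C)C(C)C` gives 660 nM. Compound 3 `COC(CCc1ccccc1)c1ccccc1OCC(O)CN1CCCCC1` carries piperidin-1-yl in place of diisopropylamino on a saturated chain carbon, two bonds along the chain from an oxygen on a saturated carbon, and gives 770 nM; the measured step was a 1.2-fold higher number from compound 1 to compound 3 (0.07 log units; within the scatter). Compound 2 `CC(C)N(CC(O)COc1ccccc1C(=O)CCc1cccc2ccccc12)C(C)C` gives 540 nM, the lowest of the three numbers, although it lies within the scatter of both compound 1 and compound 3, so no order among the three can be claimed.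

Compound 4 `CC(C)N(CC(O)COc1ccccc1C(=O)CCc1ccccc1)C(C)C` differs from compound 2 in one place: phenyl in place of naphthalen-1-yl on a saturated chain carbon, two bonds along the chain from a carbonyl carbon. Going by the values given here, no measured step touches this part of the molecule. Among the compounds with values here, the only measured step, from compound 1 to compound 3, alters the amine and stays within the scatter, and compound 1 and compound 2 differ in two places at once, so their two values cannot be split into single changes. With nothing pointing in either direction, the step expected is a 1.5-fold higher number from compound 2 to compound 4 (0.17 log units; within the scatter), most likely small and possibly within the scatter. Compound 4 is therefore estimated at about 800 nM, with a likely range from 400 nM to 1600 nM.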

Compound 4, half-maximal inhibitory concentration: 310 nM
Compound 4: middle estimate off by 2.6-fold (0.41 log units), on the high side; the whole stated range lies above it.
By their numbers in this assay, from the lowest: compounds 4, 2, 1 and 3 (each within the scatter of the next, the first and the last beyond it).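

In this assay, phenyl in place of naphthalen-1-yl on a saturated chain carbon, two bonds along the chain from a carbonyl carbon, gives a small step (a 1.7-fold lower number from compound 2 to compound 4 (0.24 log units; within the scatter)). Going by these compounds alone, this is the first step measured at this position, which the earlier compounds left untested, and the two numbers cannot be told apart. A group of 6 heavy atoms with one six-membered aromatic ring therefore reads the same here as a group of 10 heavy atoms with 2 such rings, so the second ring makes no measurable difference in this pair, and no data shown explain why.

A single pair says nothing yet about whether a ring is needed at this position at all, or whether a saturated ring such as cyclohexyl, or a pyridine ring with nitrogen in it, would give a similar number. Going by these compounds, it also remains open whether the same swap would read the same way on a compound carrying piperidin-1-yl in place of diisopropylamino.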